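The source may hold more compounds than are shown below. What is called first, only, known or untested is meant among the compounds shown, and "the series" means these compounds.

Measured in an ADME assay on J774.A1 cells (Mus musculus) for cytotoxicity, with a stated time of 48 h; a higher number here means that more compound is tolerated, a lower number that less compound is tolerated:
compound 1 `O=[N+]([O-])c1ccc(OC2C(Cn3ccnc3)CCCC2Cn2ccnc2)cc1` gives 73.9 ug/mL
compound 2 `O=[N+]([O-])c1ccc(OC2C(Cn3ccnc3)CCCC2Cn2ccnc2)c(F)c1` gives 39.4 ug/mL
compound 3 `O=[N+]([O-])c1ccc(OC2C(n3ccnc3)CCCC2n2ccnc2)cc1` gives only a limit, > 100 ug/mL

Compound 1 and compound 2 share one core, and compound 2 differs from compound 1 by fluoro in place of hydrogen on an aromatic carbon. In this assay that change made a 1.9-fold lower number from compound 1 to compound 2 (0.27 log units; within the scatter). Compound 3 is built on a different core; the difference between the two cores is not broken down here. The result for compound 3 is a limit of the assay rather than a number, and it sits at the limit of > 100 ug/mL in this assay, at which 1 of the 3 values shown sits. Compound 4 `O=[N+]([O-])c1ccc(OC2C(n3ccnc3)CCCC2n2ccnc2)c(F)c1` has not yet been measured. It stands to compound 3 as compound 2 stands to compound 1, carrying (fluoro in place of hydrogen on an aromatic carbon). This is the same change at the same place, and it occurs twice among the compounds shown. For compound 4 the expected step is an at least 1.1-fold lower number from compound 3 to compound 4 (0.07 log units; that floor lies within the scatter), resting on the earlier step of a 1.9-fold lower number from compound 1 to compound 2 (0.27 log units; within the scatter). Compound 4 is therefore estimated at 85 ug/mL, expected to fall between 40 ug/mL and 200 ug/mL, with a fair chance that the assay again reports only a limit.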

Compound 4, half-maximal cytotoxic concentration: 90.6 ug/mL
The estimate for compound 4 lay 1.1-fold (0.03 log units) below the measured number, and the stated range covers the measured number.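

On the core of compound 3, fluoro in place of hydrogen on an aromatic carbon gives, in this assay, an at least 1.1-fold lower number from compound 3 to compound 4 (0.04 log units; that floor lies within the scatter). For compound 3 the assay reports a limit and not a number: > 100 ug/mL. Set beside the same change on the core of compound 1, this step shows that nothing here separates the two cores, but it does not show that the change carries over with the same size, since only a floor is known for the second step: the same change on two cores in this assay, a 1.9-fold lower number (0.27 log units; within the scatter) from compound 1 to compound 2 and an at least 1.1-fold lower number (0.04 log units; that floor lies within the scatter) from compound 3 to compound 4; the limit leaves it open whether they differ.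

The compounds shown leave open whether a larger or different group in the same place, such as chloro or methoxy, would give a clearer step on either core. They also leave open whether fluoro would give a step beyond the usual scatter on any other core, as two cores and one change are too few to support a rule for the whole series.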